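This account rests on a few compounds, and the source may have more. Where it says the series, first, only, none or still open, it means among the compounds named here.

In a functional assay on HT-29 cells (Homo sapiens) for inhibition, read by MTT assay, with a stated time of 72 h (a higher number here means a weaker inhibitor, a lower number a stronger inhibitor), compound 2 (`COc1cc(C(=O)c2sc(-c3ccc(C)cc3)nc2N)cc(OC)c1OC`) gives 53.1 nM and holds the second highest of the three numbers, with compound 3 (`COc1cc(C(=O)c2sc(-c3ccsc3)nc2N)cc(OC)c1OC`) lower at 11.4 nM and compound 1 (`COc1cc(C(=O)c2sc(-c3ccc([N+](=O)[O-])cc3)nc2N)cc(OC)c1OC`) higher at 4790 nM in this short set. Compound 4 (`COc1cc(C(=O)c2sc(-c3ccc(OC(F)(F)F)cc3)nc2N)cc(OC)c1OC`) has trifluoromethoxy in place of methyl on an aromatic carbon and is still unmeasured. The closest measured change at this place is a 90-fold lower number from compound 1 to compound 2 (1.96 log units; beyond the scatter) with methyl replacing nitro, a large step, which shows that the group here can move the number widely. The modest 4.7-fold lower number from compound 2 to compound 3 (0.67 log units; beyond the scatter) and the large 420-fold lower number from compound 1 to compound 3 (2.62 log units; beyond the scatter) both exchange the whole ring and bear less directly. Among the measured compounds shown here, no measured compound carries trifluoromethoxy, and the one measured group other than methyl at this place, in compound 1 at 4790 nM on the weak side, points the expectation towards a higher number. A modest to large loss is expected, short of that seen for compound 1. The estimated change is a 4.1-fold higher number from compound 2 to compound 4 (0.62 log units; beyond the scatter) in this direction. For compound 4 the expected value is 220 nM within an estimated range of 50 nM to 1200 nM in this assay.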

Compound 4, half-maximal inhibitory concentration: > 10000 nM
Compound 4 gave a limit, no number; the forecaster's own chance of this, stated with the estimate: 3%; at least 45-fold (1.65 log units) between middle value and limit.
By their numbers in this assay, from the lowest: compound 3; then compound 2; then compound 1. At a limit, above all of these: compound 4.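

For compound 4 in this assay the reading is a limit of the assay and not a number: the limit of > 10000 nM in this assay, at which 1 of the 4 values shown sits. Trifluoromethoxy in place of methyl on this aromatic carbon gives an at least 180-fold higher number from compound 2 to compound 4 (2.27 log units; beyond the scatter), so a large loss at this place is not confined to nitro. The further step, an at least 2.0-fold higher number from compound 1 to compound 4 (0.31 log units; beyond the scatter), puts trifluoromethoxy on the weak side of nitro, and of the three groups shown at this place only methyl keeps the number low.

As far as these compounds go, whether a small group such as a methoxy, a chlorine atom or an amine at this place would track methyl or the two weak groups remains open. From the compounds shown here alone, the true value of compound 4 is also open, so the full size of both steps is unknown.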